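Replacing fluoro with hydrogen in compound 2

The source may report more compounds than this note shows. Statements on the series, on what has been measured and on what is new or still open speak of the compounds shown alone.

Compound 1 `Cc1nc(-c2ccccc2F)c(C(=O)N2CCN(c3cc(Cl)cc(Cl)c3)CC2)o1`: 49%
Compound 2 `COc1cc(OC)cc(N2CCN(C(=O)c3oc(C)nc3-c3ccccc3F)CC2)c1`: 16.6%
Compound 3 `CCC[C@H](Nc1nc(-c2ccc(NC(=O)NCC)c(OC)c2)ncc1C)c1cccnc1`: 87.5%

In an ADME assay on microsomes from liver (Mus musculus) for metabolic stability, read by LC-MS, with a stated time of 1 h, tested at 5 uM (a lower number here means that less of the compound is left, a higher number that more of the compound is left), compound 2 gives the lowest of the three numbers. Compound 1 is its nearest neighbour, and compound 3 lies furthest away.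

Compound 4 `COc1cc(OC)cc(N2CCN(C(=O)c3oc(C)nc3-c3ccccc3)CC2)c1` has hydrogen in place of fluoro on an aromatic carbon, ortho to a large group: hydrogen in place of fluoro on an aromatic carbon. In other words, 2-fluorophenyl becomes phenyl.

Among the measured compounds shown here, the only measured step is a number 32.4 percentage points lower from compound 1 to compound 2 (beyond the scatter). It is large, but it comes from 3,5-dimethoxyphenyl in place of 3,5-dichlorophenyl, and the 2-fluorophenyl stays the same in both compounds. It therefore says little about this change. For the measured compounds named here, compound 3 differs in too many places to supply a step, and no measured pair compares fluoro with hydrogen here.

With no direct evidence, the starting point is compound 2 at 16.6%, and no step beyond the scatter is expected. The expected step is a number 1.6 percentage points lower from compound 2 to compound 4 (within the scatter). For compound 4 the estimated value is 15%, with an expected range of 5% to 30%.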

Compound 4, percent of the compound remaining: 0.7%
Beside the measured number, compound 4's estimate is 14.3 percentage points above it; measured number outside the range, below it.
By their numbers in this assay, from the lowest: compound 4; then compound 2; then compound 1; then compound 3.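

In this assay, taking 2-fluorophenyl to phenyl moves the read-out by more than the scatter (a number 15.9 percentage points lower from compound 2 to compound 4 (beyond the scatter)), so the fluoro on this aromatic carbon is not a silent substituent in the dimethoxyphenyl series. The earlier step (a number 32.4 percentage points lower from compound 1 to compound 2 (beyond the scatter)) held 2-fluorophenyl fixed and changed only the group on the ring amine nitrogen, so the series now has a measured change at each end of the shared core, both towards less compound left. No measurement shown bears on what lies behind the new step.

On these data alone, whether hydrogen in place of fluoro gives a similar step with 3,5-dichlorophenyl in place of 3,5-dimethoxyphenyl remains open. So does the reading for other groups on this carbon, such as chloro, methyl or nitrile.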